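Methyl in place of trifluoromethyl on the shared core

The compounds below may be only part of what the source reports. "The series", "measured", "known", "first", "only" and "open" are said of these compounds alone.

Measured so far:
compound 1, `O=C1NCCN1CCN1CCC(c2cn(-c3ccc(F)cc3)c3ccc(C(F)(F)F)cc23)CC1`, 0.11 umol/kg
compound 2, `O=C1NCCN1CCCN1CCC(c2cn(-c3ccc(F)cc3)c3ccc(Cl)cc23)CC1`, 1.8 umol/kg

In a functional assay on the whole organism for inhibition, with Rattus norvegicus as the target (a lower number here means that less compound is needed, a higher number that more compound is needed for the effect), compound 1 gives the lowest of the two numbers; compound 2 differs from it in more than one place, so the two values are simply compared as they stand. Compound 3, `Cc1ccc2c(c1)c(C1CCN(CCN3CCNC3=O)CC1)cn2-c1ccc(F)cc1`, has not yet been measured. It differs from compound 1 in one place: methyl in place of trifluoromethyl on an aromatic carbon. Among the measured compounds shown here, no measured pair shows this change, so the size of its step in this assay is uncertain; a modest rise beyond the scatter is expected, a 2.7-fold higher number from compound 1 to compound 3 (0.44 log units; beyond the scatter). Compound 3 is therefore estimated at 0.3 umol/kg, in the range 0.08 umol/kg to 1.2 umol/kg.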

Compound 3, dose for half-maximal effect: 0.0083 umol/kg
Estimate against measurement, compound 3: 36-fold (1.56 log units) above; measured number below the stated range.
By their numbers in this assay, from the lowest: compound 3; then compound 1; then compound 2.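

In this assay, methyl in place of trifluoromethyl on this aromatic carbon gives a 13-fold lower number from compound 1 to compound 3 (1.12 log units; beyond the scatter), a large step beyond the scatter. This position therefore does not need trifluoromethyl for a low dose, and here the group with one heavy atom needs less compound than the group with four. No measurement available here bears on the reason for this step. The compounds shown leave open how chlorine, carried by compound 2 on a longer chain, would stand on the chain of compound 3. Also open, from the compounds shown here alone, is how ethyl or methoxy would compare with methyl at this position.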